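The source may report more compounds than this note shows. Statements on the series, on what has been measured and on what is new or still open speak of the compounds shown alone.

Compounds measured so far:
Compound 1, `O=C1C=CC2(C=C1)OCC(=O)N2c1nc(-c2ccc3ccccc3c2Br)nn1-c1ccccc1`, gives 100 nM.
Compound 2, `CC1CN(c2nc(-c3ccc4ccccc4c3)nn2-c2ccccc2)C2(C=CC(=O)C=C2)O1`, gives 320 nM.

In a functional assay on A549 cells (Homo sapiens) for antiproliferative activity, with a stated time of 5 days (a higher number here means a weaker inhibitor, a lower number a stronger inhibitor), compound 1 holds the lower of the two numbers. Compound 2 shows a higher number, and the gap between the two lies beyond the usual scatter, so on these two values compound 1 is the stronger inhibitor. Within the data shown here, the two compounds differ in more than one place, and no single step between them is worked out; nothing more is read from the pair.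

Compound 3, `O=C1C=CC2(C=C1)OCC(=O)N2c1nc(-c2cccc(Cl)c2)nn1-c1ccccc1`, is built on the core of compound 1 and differs from it in one place: 3-chlorophenyl in place of 1-bromonaphthalen-2-yl on an aromatic carbon. Among the measured compounds shown here, no measured pair in this set isolates such a change, so any expectation for this assay rests only on compound 1 and the change itself. The group that enters is smaller than the group that leaves, with one ring in place of two. The step from compound 1 to compound 3 in this assay is expected to be a 4.0-fold higher number from compound 1 to compound 3 (0.60 log units; beyond the scatter), a rise in the number beyond the scatter, toward a weaker inhibitor. Compound 3 is therefore estimated at 400 nM in this assay, with a range from 120 nM to 1500 nM.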

Compound 3, half-maximal inhibitory concentration: 25.2 nM
Beside the measured number, compound 3's estimate is 16-fold (1.20 log units) above it; the measured number lies below the stated range.
By their numbers in this assay, from the lowest: compound 3; then compound 1; then compound 2.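

Replacing 1-bromonaphthalen-2-yl with 3-chlorophenyl on the aromatic carbon of the five-membered aromatic ring with 3 nitrogen gives a 4.0-fold lower number from compound 1 to compound 3 (0.60 log units; beyond the scatter) in this assay. This position therefore does not need the second aromatic ring of compound 1 for a low number: with one ring in place of two and fewer heavy atoms, compound 3 is the stronger inhibitor of this pair. Nothing at hand gives a reason for this step.

The exchange alters the ring count, the halogen and the halogen's place all at once, so the compounds shown leave open which of these changes carries the difference; a plain phenyl or a naphthalen-2-yl without bromine at this position would begin to separate them. Also open, as far as these compounds go, is whether 3-chlorophenyl gives a similar step on the core of compound 2, and whether a phenyl ring bearing an amine or a carboxylic acid in place of chlorine would keep the number of compound 3.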